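Replacing 4-bromophenyl with 2-chlorophenyl in the series

The compounds below may be only part of what the source reports. "The series", "measured", "known", "first", "only" and "open" are said of these compounds alone.

Among the compounds with values here, in a functional assay on SK-BR-3 cells (Homo sapiens) for antiproliferative activity, read by MTT assay, with a stated time of 72 h (on this read-out higher numbers stand for weaker inhibition and lower numbers for stronger inhibition), compound 1 (`CCN1CCN(c2cc(C)c3cc(NC(=O)c4ccc(Br)cc4)ccc3n2)CC1`) gives 6310 nM as the lower of the two numbers so far, while compound 2 (`CCN(CC)c1cc(C)c2cc(NC(=O)c3ccc(Cl)c(Cl)c3)ccc2n1`) gives 41200 nM in the same read-out. Compound 3 (`CCN1CCN(c2cc(C)c3cc(NC(=O)c4ccccc4Cl)ccc3n2)CC1`) has not yet been measured. Against compound 1 it carries 2-chlorophenyl in place of 4-bromophenyl on a carbonyl carbon. Within the data shown here, no measured pair isolates this change. In this assay a small step toward weaker inhibition is expected (a 1.6-fold higher number from compound 1 to compound 3 (0.20 log units; within the scatter)). The expected value for compound 3 is 10000 nM (estimated range 3000 nM to 35000 nM).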

Compound 3, half-maximal inhibitory concentration: > 50000 nM
Compound 3 was reported as a limit (the forecaster's own chance of this, stated with the estimate: 10%); middle value at least 5.0-fold (0.69 log units) from the limit.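

In this assay, within the data shown here, the first single-place comparison shows an at least 7.9-fold higher number from compound 1 to compound 3 (0.89 log units; beyond the scatter), on swapping 4-bromophenyl for 2-chlorophenyl on the carbonyl carbon. On the core of compound 1, this position therefore does not accept every halogen-bearing phenyl equally. Compound 3 is recorded only as a limit, so the full size of the step stays unknown: the limit of > 50000 nM in this assay, at which 1 of the 3 values shown sits.

The halogen and its place on the phenyl ring change together here, and a 4-chlorophenyl amide would separate the two. Also open, from the compounds shown here alone, is how an amine or a carboxylic acid on that ring would read.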